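A few compounds are considered here, and "the series" means these few. Any claim that something is new, unique, unknown or untested is made for them only; others in the source may bear on it.

Compound 1 `O=C(COc1ccc(/C=C2\SC(=O)NC2=O)cc1)Nc1nc2ccccc2s1` gives in a functional assay on Gurav cells (Homo sapiens) for cytotoxicity, read by sulforhodamine B assay, with a stated time of 48 h (a higher number here means a weaker inhibitor of growth, a lower number a stronger inhibitor of growth), only a limit, < 100000 nM.
Compound 2 `O=C(COc1ccc(/C=C2\SC(=O)NC2=O)cc1)Nc1ncc([N+](=O)[O-])s1` gives in this assay only a limit, < 100000 nM.
Compound 3 `O=C(COc1ccc(/C=C2\SC(=O)NC2=O)cc1)Nc1ccccn1` gives in this assay only a limit, < 100000 nM.

Compound 3 therefore stands where every measured compound stands: at the limit of < 100000 nM in this assay, at which 3 of the 3 values shown sit. Compound 4 `Cc1cc(NC(=O)COc2ccc(/C=C3\SC(=O)NC3=O)cc2)no1` differs from it by 5-methyl-1,2-oxazol-3-yl in place of pyridin-2-yl on an amide-type nitrogen. The measured steps that touch the same nitrogen are a step that the two limits leave unreadable from compound 1 to compound 3, a step that the two limits leave unreadable from compound 2 to compound 3 and a step that the two limits leave unreadable from compound 1 to compound 2; none of them yields a readable size, so no direction can be drawn from them. With three limits and no number among them, the expected step that the limit leaves unreadable from compound 3 to compound 4 is set at none beyond the scatter. Compound 4 is thus estimated at 30000 nM, in the range 5000 nM to 100000 nM, with a real chance that this assay again returns only a limit.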

Compound 4, concentration for 50% growth inhibition: 38900 nM
Compound 4: the middle estimate sits 1.3-fold (0.11 log units) below what was measured; the range from low to high includes it.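

Compound 4 gives a number, but no step to it from compound 1, compound 2 or compound 3 can be read, because those three remain limits: the limit of < 100000 nM in this assay, at which 3 of the 4 values shown sit.

The compounds shown leave open how large an effect any of these amide nitrogen groups has in this assay.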